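Ethylamino to isopropylamino: clearance notes on the series

The compounds below may be only part of what the source reports. "The series", "measured", "known", "first", "only" and "open" are said of these compounds alone.

compound 1 `Nc1ccc(S(=O)(=O)c2ccc(-c3ncc(C(O)(C(F)(F)F)C(F)(F)F)cn3)cc2)cn1` gives < 14 mL.min-1.g-1 (a limit)
compound 2 `CNc1nc(S(=O)(=O)c2ccc(N)nc2)ccc1-c1ccc(C(C)(O)C(F)(F)F)cn1` gives 21 mL.min-1.g-1 (a number)
compound 3 `CCNc1nc(S(=O)(=O)c2ccc(N)nc2)ccc1-c1ccc(C(C)(O)C(F)(F)F)cn1` gives 42 mL.min-1.g-1 (a number)

The value of compound 1 is a limit of the assay and not a number. Among the measured compounds shown here, in an ADME assay (liver) for metabolic stability, with Liver microsome (Rattus norvegicus) as the target, using microsomes and NADPH, with a stated time of 30 min, at 37 degrees C, tested at 1 uM (a lower number here means slower removal, a higher number faster removal of the compound), compound 3 at 42 mL.min-1.g-1 sits within the scatter of compound 2 at 21 mL.min-1.g-1 and these are the only two numbers in hand. Going to compound 4 `CC(C)Nc1nc(S(=O)(=O)c2ccc(N)nc2)ccc1-c1ccc(C(C)(O)C(F)(F)F)cn1` turns ethylamino into isopropylamino, with methyl in place of hydrogen on a saturated chain carbon bound to a nitrogen on an aromatic ring and a saturated chain carbon as the difference. For the measured compounds named here, the one measured step of this kind is a 2.0-fold higher number from compound 2 to compound 3 (0.30 log units; within the scatter) and it also puts a methyl in place of hydrogen. The step expected here is a 1.2-fold higher number from compound 3 to compound 4 (0.09 log units; within the scatter) and so no shift beyond the scatter is anticipated. Compound 4 is estimated at 52 mL.min-1.g-1 with a range from 27 mL.min-1.g-1 to 100 mL.min-1.g-1 as the expected span.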

Compound 4, intrinsic clearance in microsomes: 62 mL.min-1.g-1
Beside the measured number, compound 4's estimate is 1.2-fold (0.08 log units) below it; the measured number falls inside the stated range.
By their numbers in this assay, from the lowest: compounds 2, 3 and 4 (each within the scatter of the next, the first and the last beyond it). At a limit, below all of these: compound 1.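

In this assay, adding a methyl to the ethylamino chain gives a 1.5-fold higher number from compound 3 to compound 4 (0.17 log units; within the scatter), so this single change cannot be told from repeat measurement. Read across the series, though, isopropyl in place of methyl on the nitrogen gives a 3.0-fold higher number from compound 2 to compound 4 (0.47 log units; beyond the scatter), the first shift at this position to clear the scatter, reached through two steps that each stay within it. Nothing measured here bears on the cause of that shift.

As far as these compounds go, whether a cyclopropyl, a tert-butyl or a hydroxyethyl group on that nitrogen would carry the number further or bring it back stays open.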